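Reintroducing a hydroxyl on the sugar-like ring: compound 3

This account rests on a few compounds, and the source may have more. Where it says the series, first, only, none or still open, it means among the compounds named here.

Two compounds of the series have been run in an assay on isolated protein for inhibition of DNA topoisomerase 1 (Homo sapiens), with a stated time of 30 min, tested at 100 uM; a higher number here means more inhibition at the concentration tested (going by the name of the read-out), a lower number less inhibition. Compound 1 `C[C@@H]1O[C@@H](OCC#Cc2c(-c3ccccc3)sc3ccccc23)C[C@H](N)[C@H]1O` gives 32.2% in this assay. Compound 2 `C[C@@H]1O[C@@H](OCC#Cc2c(-c3ccccc3)sc3ccccc23)CC[C@@H]1N`, which carries the smaller ring group, gives 7.9%. Among the measured compounds shown here, compound 2 thus stands lowest of the two numbers, with compound 1 above it beyond the scatter; the single step of a number 24.3 percentage points lower from compound 1 to compound 2 (beyond the scatter) is the only measured change so far.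

Compound 3 `C[C@@H]1O[C@@H](OCC#Cc2c(-c3ccccc3)sc3ccccc23)C[C@H](N)[C@@H]1O` is the next member to be measured. Relative to compound 2 the change is a group of 9 heavy atoms (6 carbon, 1 nitrogen, 2 oxygen; one six-membered non-aromatic ring with 1 hetero atom) in place of a group of 8 heavy atoms (6 carbon, 1 nitrogen, 1 oxygen; one six-membered non-aromatic ring with 1 hetero atom), on an oxygen on a saturated carbon. The entering group matches the composition of the ring group in compound 1 and differs from it in the arrangement of its defined stereocentres.

The step from compound 1 to compound 2 is the one that bears on this change, since it removed the same kind of oxygen-bearing ring group that now returns. Because a number 24.3 percentage points lower from compound 1 to compound 2 (beyond the scatter) was a modest loss, a recovery of similar size is expected on returning the group, expressed as a number 17.1 percentage points higher from compound 2 to compound 3 (beyond the scatter); the differing stereochemistry leaves the size uncertain. Compound 3 is estimated at 25%, within a range of 8% to 42%.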

Compound 3, a percentage reported as inhibition, at one concentration (the size of the read-out at that concentration, not a potency): 36.9%
The estimate for compound 3 lay 11.9 percentage points below the measured number; the measured number falls inside the stated range.
By their numbers in this assay, from the lowest: compound 2; then compounds 1 and 3 (each within the scatter of the next).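

In this assay, the ring group of 9 heavy atoms now stands above the 5-amino-6-methyloxan-2-yl group in a second pair, with a number 29 percentage points higher from compound 2 to compound 3 (beyond the scatter) adding to the earlier reading of a number 24.3 percentage points lower from compound 1 to compound 2 (beyond the scatter). The one stereocentre that differs, at a saturated ring carbon and drawn R against S, shows no readable effect at the concentration tested, with a number 4.7 percentage points higher from compound 1 to compound 3 (within the scatter). The gain over compound 2 therefore goes with the presence of the extra hydroxyl in the group and does not depend on how that one stereocentre is drawn, and the pair that supports this reading is a clean one: the fact that compounds 1 and 3 differ only in the configuration as drawn.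

Readings at a single concentration give no potency, and the compounds shown leave open how much of the inhibition depends on the ring amine. As far as these compounds go, it also remains open whether a methoxy group in place of the hydroxyl, or an acetamide in place of the amine, would keep the number near that of compound 3 at 36.9%.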